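From a branched ester to an acetylethenyl side chain

The compounds below may be only part of what the source reports. "The series", "measured", "known", "first", "only" and "open" are said of these compounds alone.

Values measured in a functional assay on SEM cells (Homo sapiens) for cytotoxicity, with a stated time of 72 h (on this read-out lower numbers stand for an effect already at smaller amounts and higher numbers for an effect only at larger amounts of compound), are as follows
compound 1 (`COc1ccc(/C=C/[C@@](C)(/C=C/c2ccc(O)c(/C=C/C#N)c2)CCC=C(C)C)cc1`) gives 4540 nM
compound 2 (`CCOC(=O)/C=C/c1cc(/C=C/[C@](C)(/C=C/c2ccc(OC)cc2)CCC=C(C)C)ccc1O`) gives > 36600 nM (a limit)
compound 3 (`CCOC(=O)/C(C)=C/c1cc(/C=C/[C@](C)(/C=C/c2ccc(OC)cc2)CCC=C(C)C)ccc1O`) gives > 36600 nM (a limit)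

Compound 3 stands at the limit of > 36600 nM in this assay, at which 2 of the 3 values shown sit, and so has a limit rather than a number. Compound 4 (`COc1ccc(/C=C/[C@@](C)(/C=C/c2ccc(O)c(/C=C/C(C)=O)c2)CCC=C(C)C)cc1`) has not yet been measured. It carries 2-acetylethenyl in place of 2-(ethoxycarbonyl)prop-1-en-1-yl on an aromatic carbon.

Going by the values given here, two measured steps bear most directly on this change. Ethoxycarbonyl in place of cyano gives an at least 8.0-fold higher number from compound 1 to compound 2 (0.90 log units; beyond the scatter) and the exchange of the whole side chain gives an at least 8.0-fold higher number from compound 1 to compound 3 (0.90 log units; beyond the scatter) in this assay. The remaining step gives a step that the two limits leave unreadable from compound 2 to compound 3 and so says nothing about the added methyl group.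

Among these three, only the nitrile reads as a number, and both esters stop at the limit. Compound 4 has no ester, so it is expected to move towards compound 1 at 4540 nM in this assay. Among the compounds with values here, no measured compound carries the acetyl group, so the expectation stays broad. The expected size is an at least 5.2-fold lower number from compound 3 to compound 4 (0.71 log units; beyond the scatter) and points to a lower number. The estimate for compound 4 is 7000 nM in an expected range from 1800 nM to 30000 nM (not yet measured).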

Compound 4, half-maximal effective concentration: 8670 nM
For compound 4 the middle estimate is 1.2-fold (0.09 log units) below the measured one; the measured number falls inside the stated range.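

On the aromatic carbon ortho to the hydroxy group, the nitrile turns out not to be the only side chain that gives a readable number in this assay: 2-acetylethenyl in place of 2-(ethoxycarbonyl)prop-1-en-1-yl gives an at least 4.2-fold lower number from compound 3 to compound 4 (0.62 log units; beyond the scatter). The narrower exchange, methyl in place of ethoxy on the carbonyl carbon, gives an at least 4.2-fold lower number from compound 2 to compound 4 (0.62 log units; beyond the scatter), so this one change at the carbonyl carbon is enough to bring the value off the limit. Acetyl in place of cyano gives a 1.9-fold higher number from compound 1 to compound 4 (0.28 log units; within the scatter), so the ketone and the nitrile cannot be told apart here, and among the four compounds only the two esters stand apart, each with a limit rather than a number: the limit of > 36600 nM in this assay, at which 2 of the 4 values shown sit.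

The compounds shown leave open whether a carboxylic acid, an amide or a methyl ester on the same carbonyl carbon would read like the ketone or like the ethyl esters. As far as these compounds go, how far compound 2 and compound 3 lie beyond their limits also stays unknown, so the full size of the steps from them to compound 4 remains open.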